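This account rests on a few compounds, and the source may have more. Where it says the series, first, only, none or still open, it means among the compounds named here.

Measured so far:
- Compound 1 `CC/N=C1\S/C(=C\c2cc(C)n(-c3ccccc3)c2C)C(=O)N1CC`: 237 nM
- Compound 2 `C/N=C1\S/C(=C\c2cc(C)n(-c3ccc(F)cc3)c2C)C(=O)N1C`: 652 nM
- Compound 3 `C/N=C1\S/C(=C\c2cc(C)n(Cc3ccc(F)cc3F)c2C)C(=O)N1C`: 37 nM

These three compounds were tested in a functional assay for agonist activity at sphingosine 1-phosphate receptor 5 (Homo sapiens); on this read-out higher numbers stand for an effect only at larger amounts of compound and lower numbers for an effect already at smaller amounts. Compound 1 gives 237 nM and stands second highest of the three numbers: compound 2 gives the higher number, 652 nM, and compound 3 gives the lowest number of the set, 37 nM. The step to compound 4 `CC/N=C1\S/C(=C\c2cc(C)n(Cc3c(F)cccc3F)c2C)C(=O)N1CC` is a single change on the shared core: 2,6-difluorobenzyl in place of phenyl on an aromatic nitrogen. Among the compounds with values here, no measured pair shows exactly this change, but compound 3, the only benzyl-bearing compound, holds the lowest number of the set. On that basis the step from compound 1 to compound 4 is expected to lower the number, a 4.7-fold lower number from compound 1 to compound 4 (0.68 log units; beyond the scatter), beyond the scatter. Compound 4 is therefore estimated to give 50 nM, with a likely range from 15 nM to 160 nM.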

Compound 4, half-maximal effective concentration: 22 nM
The estimate for compound 4 lay 2.3-fold (0.36 log units) above the measured number; the range from low to high includes it.
By their numbers in this assay, from the lowest: compounds 4 and 3 (each within the scatter of the next); then compound 1; then compound 2.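

In this assay, placing 2,6-difluorobenzyl in place of phenyl on the aromatic nitrogen gives an 11-fold lower number from compound 1 to compound 4 (1.03 log units; beyond the scatter), a large step. Within the data shown here, this is the first direct reading of this change with the rest of the shared core held constant, and it shows that the number at this position depends strongly on the group attached. No available evidence explains the drop. The step cannot separate the contribution of the benzyl link from that of the two fluorines, and plain benzyl is not among these compounds. From the compounds shown here alone, how a longer chain such as phenethyl would read at this nitrogen also remains open.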